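This account rests on a few compounds, and the source may have more. Where it says the series, first, only, none or still open, it means among the compounds named here.

Compound 1 `CCCCN(CC)c1cc(C)nc2c1NC(=O)CN2c1ccc(C)cc1Cl` in an assay on HEK-293T cells for displacement of a labelled ligand from corticotropin-releasing factor receptor 1 (Homo sapiens), read by scintillation counting, with a stated time of 2 h (a higher number here means a weaker inhibitor, a lower number a stronger inhibitor), gives 4.4 nM.
Compound 2 `CCCCN(CC)c1cc(C)nc2c1NC(=O)CN2c1ccc(C)cc1C` in this assay gives 3.9 nM.
Compound 3 `CCN(C)c1cc(C)nc2c1NC(=O)CN2c1ccc(C(C)C)cc1Br` in this assay gives 16.4 nM.

Compound 2 has the lowest of the three numbers, but its gap to compound 1 is within the scatter, so the two cannot be ranked; only compound 3 sits beyond the scatter, with the higher number. Compound 4 `CCCCN(CC)c1cc(C)nc2c1NC(=O)CN2c1ccc(Br)cc1Cl` differs from compound 2 by 4-bromo-2-chlorophenyl in place of 2,4-dimethylphenyl on a nitrogen on an aromatic ring in a ring. For the measured compounds named here, one measured step bears on this change: a 1.1-fold lower number from compound 1 to compound 2 (0.05 log units; within the scatter), which exchanged methyl and chloro on the same ring and stayed within the scatter. Going by the values given here, no measured pair isolates a bromo for methyl exchange on this ring. Compound 4 is therefore expected to move little, a 1.4-fold higher number from compound 2 to compound 4 (0.15 log units; within the scatter), and its estimated value in this assay is 5.5 nM (range 2 nM to 15 nM).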

Compound 4, inhibition constant: 2.7 nM
Compound 4: the middle estimate sits 2.0-fold (0.31 log units) above what was measured; the measured number falls inside the stated range.
By their numbers in this assay, from the lowest: compounds 4, 2 and 1 (each within the scatter of the next); then compound 3.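

In this assay, for the compounds shown here, a 1.6-fold lower number from compound 1 to compound 4 (0.21 log units; within the scatter) comes with the single exchange of methyl for bromo on the aromatic ring, and a 1.4-fold lower number from compound 2 to compound 4 (0.16 log units; within the scatter) comes with two groups on that ring exchanged at once. Bromo therefore joins methyl and chloro as a group that cannot be told apart in these compounds, and even the double exchange stays within the scatter.

Going by these compounds, whether a methoxy group or a nitrile in place of the bromo would keep the number this low remains open. Nothing measured here explains why these steps are so small.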